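Cyclohexyl for oxan-4-yl on an aromatic nitrogen

This account rests on a few compounds, and the source may have more. Where it says the series, first, only, none or still open, it means among the compounds named here.

Measured in a functional assay on MCF7 cells (Homo sapiens) for inhibition, read by MTT assay, with a stated time of 5 days; on this read-out higher numbers stand for weaker inhibition and lower numbers for stronger inhibition:
- compound 1 `Cc1cc(Nc2nc(NCc3ccc(F)cc3)nc3[nH]ncc23)n[nH]1`: 970 nM
- compound 2 `Cc1cc(Nc2nc(NCc3ccc(Cl)cc3)nc3c2cnn3C2CCOCC2)n[nH]1`: 1550 nM
- compound 3 `Cc1cc(Nc2nc(NCc3ccc(F)cc3F)nc3c2cnn3C2CCOCC2)n[nH]1`: 360 nM

Compound 3 has the lowest number of the three, and compound 1 is the nearest to it. Compound 4 `Cc1cc(Nc2nc(NCc3ccc(F)cc3F)nc3c2cnn3C2CCCCC2)n[nH]1` carries cyclohexyl in place of oxan-4-yl on an aromatic nitrogen. For the measured compounds named here, no measured step changes the group at this place. Going by the values given here, the one step available, a 4.3-fold lower number from compound 2 to compound 3 (0.63 log units; beyond the scatter), concerns 4-chlorophenyl and 2,4-difluorophenyl, so it shows only what size a single change can reach in this small set. In this assay, on these data alone, no step beyond the scatter is expected, and the direction stays open. The expected step is a 1.1-fold higher number from compound 3 to compound 4 (0.05 log units; within the scatter). Compound 4 is estimated at 400 nM, with an expected range of 130 nM to 1200 nM.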

Compound 4, half-maximal inhibitory concentration: 810 nM
For compound 4 the middle estimate is 2.0-fold (0.31 log units) below the measured one; measured number inside the range.
By their numbers in this assay, from the lowest: compound 3; then compounds 4, 1 and 2 (each within the scatter of the next).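

In this assay, for the compounds shown here, cyclohexyl in place of oxan-4-yl on an aromatic nitrogen gives a 2.3-fold higher number from compound 3 to compound 4 (0.35 log units; beyond the scatter), the first measured step at this position, which shows that the number responds to this change. The two groups have the same heavy-atom count and differ in the ring oxygen, the single hydrogen-bond acceptor of oxan-4-yl, which carbon replaces. Nothing available explains the step. On these data alone, whether a piperidin-4-yl group, with a ring nitrogen, or a smaller methyl group would keep the lower number remains open. As far as these compounds go, whether the step holds with 4-chlorophenyl in place of 2,4-difluorophenyl is also open.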